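Ester to amide step toward compound 3

A few compounds are considered here, and "the series" means these few. Any claim that something is new, unique, unknown or untested is made for them only; others in the source may bear on it.

Measured so far:
compound 1, `COc1ccc([N+](=O)[O-])cc1CSc1nc2cc(NC(=O)NC3CC3)ccc2n1C(C)C`, 1600 nM
compound 2, `CCCn1c(SCc2cc([N+](=O)[O-])ccc2OC)nc2cc(NC(=O)NC(C)(C)C)cc(C(=O)OC)c21`, 280 nM

In an assay on isolated protein for inhibition of Gonadotropin-releasing hormone receptor (Rattus norvegicus) (on this read-out higher numbers stand for weaker inhibition and lower numbers for stronger inhibition), compound 2 gives the lower of the two numbers; compound 1 gives a higher number, a gap beyond the usual scatter. Among the measured compounds shown here, no two measured compounds differ in a single place, so no isolated structural step has yet been observed. Compound 3, `CCCn1c(SCc2cc([N+](=O)[O-])ccc2OC)nc2cc(NC(=O)NC(C)(C)C)cc(C(=O)NCCCN(C)C)c21`, is the untested member. It differs from compound 2 by (3-(dimethylamino)propyl)amino in place of methoxy on a carbonyl carbon, with the rest of the shared core kept. For the measured compounds named here, with no comparable step measured, the size of the change is open; the expectation is a modest move toward a lower number in this assay, near the edge of the scatter, with a larger move in either direction not excluded. For compound 3 the estimated value in this assay is 150 nM, with a range from 40 nM to 600 nM. This corresponds to an expected step of a 1.9-fold lower number from compound 2 to compound 3 (0.27 log units; within the scatter).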

Compound 3, half-maximal inhibitory concentration: 19 nM
Compound 3: middle estimate off by 7.9-fold (0.90 log units), on the high side; the whole stated range lies above it.
By their numbers in this assay, from the lowest: compound 3; then compound 2; then compound 1.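

In this assay, the series now has its first single-place step: (3-(dimethylamino)propyl)amino in place of methoxy on a carbonyl carbon gives a 15-fold lower number from compound 2 to compound 3 (1.17 log units; beyond the scatter), a large move. Compound 1 and compound 2 differ in more than one place, so they could not show that this carbonyl position alone can shift the read-out so far, or that it accepts the longer (3-(dimethylamino)propyl)carbamoyl in place of methoxycarbonyl without loss. No supporting measurement bears on which part of the change accounts for the step.

The step changes the ester to an amide and adds both a chain and a terminal dimethylamine at once, so their shares remain unseparated. A simple methyl amide, a shorter chain ending in the same amine, or a carboxylic acid on this carbonyl carbon would help separate them.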